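Swapping the Aryl Ring at a Saturated Ring Carbon

A few compounds are considered here, and "the series" means these few. Any claim that something is new, unique, unknown or untested is made for them only; others in the source may bear on it.

Compound 1 `CCCOC(=O)C1=C(C)NC(=O)NC1c1ccoc1` and compound 2 `CCCOC(=O)C1=C(C)NC(=O)NC1c1cccs1` share one core; in an assay on membranes from HeLa cells for displacement of a labelled ligand from adenosine receptor A3 (Homo sapiens), read by scintillation counting, with a stated time of 180 min, tested at 1 uM (on this read-out higher numbers stand for more inhibition at the one concentration tested (going by the name of the read-out) and lower numbers for less inhibition), compound 1 gives 11% and compound 2 gives 32%. The change between them, (thiophen-2-yl in place of furan-3-yl on a saturated ring carbon), produced a step of a number 21 percentage points higher from compound 1 to compound 2 (beyond the scatter). Compound 3 `CC1=C(c2ncc(C)o2)C(c2ccoc2)NC(=O)N1` differs from compound 1 by 5-methyl-1,3-oxazol-2-yl in place of propoxycarbonyl on a double-bonded ring carbon; in this assay compound 3 gives 1%, a step of a number 10 percentage points lower from compound 1 to compound 3 (within the scatter). Compound 4 `CC1=C(c2ncc(C)o2)C(c2cccs2)NC(=O)N1` carries the same kind of change relative to compound 3, (thiophen-2-yl in place of furan-3-yl on a saturated ring carbon), though here the saturated ring carbon is next to the ring atom that bears a 5-methyl-1,3-oxazol-2-yl group rather than the ring atom that bears a propoxycarbonyl group. Resting on the step of a number 21 percentage points higher from compound 1 to compound 2 (beyond the scatter), the expected step is a number 17 percentage points higher from compound 3 to compound 4 (beyond the scatter) in this assay. Compound 4 is estimated at 18%, with a range from 3% to 35%.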

Compound 4, a percentage reported as inhibition, at one concentration (the size of the read-out at that concentration, not a potency): 1%
Compound 4: the middle estimate sits 17 percentage points above what was measured, and the stated range ends above it.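

Thiophen-2-yl in place of furan-3-yl gave no change at the digits printed from compound 3 to compound 4 (within the scatter) in this assay, so the gain seen on the core of compound 1 did not carry over to the core of compound 3: the same change on two cores in this assay, a number 21 percentage points higher (beyond the scatter) from compound 1 to compound 2 and no change at the digits printed (within the scatter) from compound 3 to compound 4, 21 percentage points apart, beyond the scatter of two such steps. Read the other way, 5-methyl-1,3-oxazol-2-yl in place of propoxycarbonyl gave a number 31 percentage points lower from compound 2 to compound 4 (beyond the scatter), so the size of that change also differed with the group on the saturated ring carbon: the same change on two cores in this assay, a number 10 percentage points lower (within the scatter) from compound 1 to compound 3 and a number 31 percentage points lower (beyond the scatter) from compound 2 to compound 4, 21 percentage points apart, beyond the scatter of two such steps. This rests on one pair of cores at a single concentration, and it does not show why the steps differ.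

The compounds shown leave open whether the thiophen-2-yl gain would return with an ethoxycarbonyl group or an amide on the double-bonded ring carbon. Going by these compounds, how a phenyl ring on the saturated ring carbon would behave on either core also stays open.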